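Side-chain swap on the shared core: stability notes

The source may hold more compounds than are shown below. What is called first, only, known or untested is meant among the compounds shown, and "the series" means these compounds.

- compound 1 `N#Cc1cnc(NCc2cnccc2C(F)(F)F)cc1N[C@H]1CC[C@@H](O)CC1`: 33%
- compound 2 `N#Cc1cnc(NCc2cnccc2C(F)(F)F)cc1NC[C@H]1CC[C@H](O)CC1`: 32%

In an ADME assay on S9 fraction from liver (Homo sapiens) for metabolic stability, with a stated time of 1 h (on this read-out higher numbers stand for a more stable compound and lower numbers for a less stable compound), compound 2 gives 32%, within the scatter of compound 1 at 33%. Compound 3 `N#Cc1cnc(NCc2cnccc2C(F)(F)F)cc1NC1CCOCC1` is the next to be read, and the change from compound 2 is oxan-4-yl in place of (4-hydroxycyclohexyl)methyl on a nitrogen on an aromatic ring. For the measured compounds named here, only one measured step bears on this, at the same place: a number 1 percentage points lower from compound 1 to compound 2 (within the scatter). That step keeps the hydroxycyclohexyl ring and alters only the attachment. Going by the values given here, no measured compound carries oxan-4-yl, so the evidence for this change is thin. A small rise, not clearly beyond the scatter, is expected, with the estimated step being a number 8 percentage points higher from compound 2 to compound 3 (within the scatter). For compound 3 the estimated value is 40%, with an expected range of 22% to 62%.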

Compound 3, percent of the compound remaining: 91%
For compound 3 the middle estimate is 51 percentage points below the measured one, outside the stated range (above it).
By their numbers in this assay, from the lowest: compounds 2 and 1 (each within the scatter of the next); then compound 3.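

In this assay, the place on a nitrogen on an aromatic ring proves highly sensitive to the ring it carries: oxan-4-yl in place of (4-hydroxycyclohexyl)methyl gives a number 59 percentage points higher from compound 2 to compound 3 (beyond the scatter), and oxan-4-yl in place of 4-hydroxycyclohexyl gives a number 58 percentage points higher from compound 1 to compound 3 (beyond the scatter). Changing only the attachment of the hydroxycyclohexyl ring gave a number 1 percentage points lower from compound 1 to compound 2 (within the scatter), so the large steps appear only where the ring of carbon only gives way to the ring with a hetero atom. Nothing available explains the size of these steps.

Compound 3 differs from both earlier compounds in its ring and in having no hydrogen-bond donor on this group, so the compounds shown do not separate these two changes. From the compounds shown here alone, whether a plain cyclohexyl group or a piperidin-4-yl amine at this place would behave like oxan-4-yl stays open.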